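Cyano in place of chloro on compound 2

This account rests on a few compounds, and the source may have more. Where it says the series, first, only, none or still open, it means among the compounds named here.

In an ADME assay on HUVEC cells (Homo sapiens) for inhibition, read by CCK-8 assay, with a stated time of 24 h, in the presence of a further agent that is not named here (a lower number here means a stronger inhibitor, a higher number a weaker inhibitor), compound 1 `Cc1cccc(-n2cc(-c3ccc(/C=C4\C(=O)Nc5ccccc54)cc3)nn2)c1` gives 13700 nM. Compound 2 `O=C1Nc2ccccc2/C1=C/c1ccc(-c2cn(-c3ccccc3Cl)nn2)cc1` gives > 20000 nM, which is a limit of the assay and not a number. Compound 3 `N#Cc1ccccc1-n1cc(-c2ccc(/C=C3\C(=O)Nc4ccccc43)cc2)nn1` carries cyano in place of chloro on an aromatic carbon of compound 2: cyano in place of chloro on an aromatic carbon. Among the compounds with values here, the only measured step that bears on this is an at least 1.4-fold higher number from compound 1 to compound 2 (0.16 log units; that floor lies within the scatter), a small one that changes a different group, so only a small move is expected in this assay. The expected step is an at least 1.2-fold lower number from compound 2 to compound 3 (0.09 log units; that floor lies within the scatter), with nothing beyond the scatter foreseen. For compound 3 the estimated value is 16000 nM, with an expected range of 7000 nM to 30000 nM.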

Compound 3, half-maximal inhibitory concentration: 19700 nM
Estimate against measurement, compound 3: 1.2-fold (0.09 log units) below, and the stated range covers the measured number.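

In this assay compound 2 stands at a limit of the assay and not at a number: the limit of > 20000 nM in this assay, at which 1 of the 3 values shown sits.

Cyano in place of chloro at this position gives an at least 1.0-fold lower number from compound 2 to compound 3 (0.00 log units; that floor lies within the scatter), so the change shows no gain that can be read. Set against the 3-methylphenyl group, the 2-cyanophenyl group gives a 1.4-fold higher number from compound 1 to compound 3 (0.16 log units; within the scatter), and compound 1 and compound 3 cannot be told apart.

Still open, going by these compounds, is whether any group on this aromatic carbon moves the number beyond the scatter. What an amine or a carboxylic acid would do there is also unknown.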